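The source may report more compounds than this note shows. Statements on the series, on what has been measured and on what is new or still open speak of the compounds shown alone.

Of the compounds shown here, two have been measured in an assay on liver for inhibition of sterol O-acyltransferase 1 (Rattus norvegicus), using microsomes (on this read-out higher numbers stand for weaker inhibition and lower numbers for stronger inhibition), so far. Compound 1, `CCCCCCCCCCCCn1nnc(C(C(=O)Nc2c(OC)cc(OC)cc2OC)c2ccc(-c3ccccc3)cc2)n1`, gives 221 nM, the highest of the two numbers. Compound 2, `CCCCCCCCCCCCn1nnc(C(C(=O)Nc2c(C(C)C)cccc2C(C)C)c2ccccn2)n1`, gives 26 nM in this assay, a gap that lies beyond the scatter. Compound 3, `CCCCCCCCCCCCn1nnc(CC(=O)Nc2c(OC)cc(OC)cc2OC)n1`, has not yet been measured; it differs from compound 1 by hydrogen in place of 4-phenylphenyl on a saturated chain carbon bound to an aromatic carbon and a carbonyl carbon. Within the data shown here, no measured pair shows the loss of a group of this size, so the expectation rests on the change itself: an expected step toward weaker inhibition from compound 1 to compound 3 of a 14-fold higher number from compound 1 to compound 3 (1.13 log units; beyond the scatter). Compound 3 is estimated at 3000 nM, within 800 nM to 12000 nM.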

Compound 3, half-maximal inhibitory concentration: 24 nM
Beside the measured number, compound 3's estimate is 130-fold (2.10 log units) above it, and the stated range ends above it.
By their numbers in this assay, from the lowest: compounds 3 and 2 (each within the scatter of the next); then compound 1.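

In this assay, putting hydrogen in place of 4-phenylphenyl on the saturated chain carbon bound to an aromatic carbon and a carbonyl carbon gives a 9.2-fold lower number from compound 1 to compound 3 (0.96 log units; beyond the scatter) and so moves toward stronger inhibition. Inhibition at this position therefore does not depend on a large group with two aromatic rings, and in this pair that group goes with weaker inhibition. Nothing available explains why the number falls. On these data alone, whether a methyl group or a single phenyl ring on this carbon would give a lower or a higher number remains open. So does the effect of an amine or a carboxylic acid there.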